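The source may hold more compounds than are shown below. What is called first, only, known or untested is meant among the compounds shown, and "the series" means these compounds.

Measured compounds:
- compound 1, `COC(=O)CCCNC(=O)CN1CN(c2ccccc2)C2(CCN(C(=O)c3ccc(C4CCCCC4)cc3)CC2)C1=O`, 2500 nM
- compound 2, `CC(C)(C)c1ccc(C(=O)N2CCC3(CC2)C(=O)N(CC(=O)N2CCCCC2CCO)CN3c2ccccc2)cc1`, 6100 nM
- compound 3, `COC(=O)CCCNC(=O)CN1CN(c2ccccc2)C2(CCN(C(=O)c3ccc(C(C)(C)C)cc3)CC2)C1=O`, "not determined" (no result reported)

In an assay on HEK293 cells for displacement of a labelled ligand from NPC1-like intracellular cholesterol transporter 1 (Homo sapiens) (on this read-out lower numbers stand for stronger inhibition and higher numbers for weaker inhibition), compound 1 gives 2500 nM, the lowest of the two numbers available. Compound 2 gives 6100 nM in this assay, a weaker result, and the gap between the two lies beyond the usual scatter of such measurements. For compound 3 no number is available, so nothing can be said of where it stands.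

Compound 4, `CS(=O)(=O)NCCCNC(=O)CN1CN(c2ccccc2)C2(CCN(C(=O)c3ccc(C4CCCCC4)cc3)CC2)C1=O`, is not yet measured. It differs from compound 1 in one place: methanesulfonamido in place of methoxycarbonyl on a saturated chain carbon, three bonds along the chain from an amide-type nitrogen. For the measured compounds named here, no step between two measured compounds covers such a change, so there is nothing in the numbers to point to a direction. The expectation for compound 4 is therefore a step of about no change at the digits printed from compound 1 to compound 4 (within the scatter), that is, none beyond the scatter. Compound 4 is estimated to give about 2500 nM in this assay, expected to fall between 900 nM and 7000 nM.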

Compound 4, half-maximal inhibitory concentration: 3800 nM
Beside the measured number, compound 4's estimate is 1.5-fold (0.18 log units) below it; low and high end bracket the measured number.
By their numbers in this assay, from the lowest: compounds 1, 4 and 2 (each within the scatter of the next, the first and the last beyond it).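

For the compounds shown here, this pair gives the first comparison in which only one place changes. In this assay, methanesulfonamido in place of methoxycarbonyl on the saturated chain carbon gives a 1.5-fold higher number from compound 1 to compound 4 (0.18 log units; within the scatter), so this place accepts a group that brings in sulfur, nitrogen and a hydrogen-bond donor without a shift beyond the scatter. Nothing on hand explains why the two groups read so much alike.

The compounds shown do not tell how a carboxylic acid, an amine or a plain methyl group would read in this place, or what a shorter or longer chain would do. They also leave open whether the same exchange would read alike on compounds carrying tert-butyl instead of cyclohexyl on the benzoyl ring.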